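Urea series: iodo in place of acetyl

This account rests on a few compounds, and the source may have more. Where it says the series, first, only, none or still open, it means among the compounds named here.

For the measured compounds named here, compound 2 `CC(=O)c1ccc(NC(=O)N[C@@H](C)c2ccccc2)cc1` stands highest of the two numbers so far in an ADME assay on the whole organism with Oryza sativa as the target, tested at 10 uM (a lower number here means a stronger effect, a higher number a weaker effect of the compound at the concentration tested), giving 96%; compound 1 `CCCCc1ccc(NC(=O)N[C@@H](C)c2ccccc2)cc1` gives 60%. Going by the values given here, the single measured step, a number 36 percentage points higher from compound 1 to compound 2 (beyond the scatter), is the only bearing one. Compound 3 `C[C@H](NC(=O)Nc1ccc(I)cc1)c1ccccc1` follows with iodo in place of acetyl on an aromatic carbon, which takes away the acetyl that separates compound 2 from compound 1. Among the compounds with values here, because a number 36 percentage points higher from compound 1 to compound 2 (beyond the scatter) was large, some reversal is expected for compound 3 rather than no step, though nothing shows how iodo compares with butyl. Compound 3 is therefore estimated at 75%, within 45% to 100%, a step of a number 21 percentage points lower from compound 2 to compound 3 (beyond the scatter).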

Compound 3, a percentage reported as activity, at one concentration (the size of the read-out at that concentration, not a potency): 95%
Estimate against measurement, compound 3: 20 percentage points below; measured number inside the range.
By their numbers in this assay, from the lowest: compound 1; then compounds 3 and 2 (each within the scatter of the next).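

In this assay the change from acetyl to iodo gives a number 1 percentage points lower from compound 2 to compound 3 (within the scatter) and does not separate the two groups at this position. Iodo in place of butyl gives a number 35 percentage points higher from compound 1 to compound 3 (beyond the scatter), so a large step away from butyl is not confined to acetyl. Of the three groups, only butyl, in compound 1, stands apart. No measurement shown accounts for this. Still open, going by these compounds, is whether an amine, a carboxylic acid or a shorter chain such as ethyl at this position would read with butyl or with acetyl and iodo.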